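A Methyl Shift on the Triazole-Bound Phenyl

The compounds below may be only part of what the source reports. "The series", "measured", "known", "first", "only" and "open" are said of these compounds alone.

compound 1 `N#CC1=C(N)Oc2c(c3nc4ccccc4nc3c3ccccc23)C12C(=O)N(Cc1cnnn1-c1cccc(Br)c1)c1ccccc12`: > 50000 nM
compound 2 `Cc1ccccc1-n1nncc1CN1C(=O)C2(C(C#N)=C(N)Oc3c(N)cc4nc5ccccc5nc4c32)c2ccccc21`: > 50000 nM

Of the compounds shown here, two have been tested so far. In a functional assay on MCF7 cells (Homo sapiens) for antiproliferative activity, read by MTT assay, with a stated time of 48 h (a lower number here means a stronger inhibitor, a higher number a weaker inhibitor), compound 1 reaches only a limit of the assay, > 50000 nM, and no number. Compound 2, in this assay, likewise stops at a limit, > 50000 nM. Within the data shown here, compound 2 therefore stands where every recorded value stands, at the ceiling of the measurement (the limit of > 50000 nM in this assay, at which 2 of the 2 values shown sit), so nothing distinguishes it from compound 1 in this assay, and no step between measured compounds can be drawn.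

Compound 3, `Cc1cccc(-n2nncc2CN2C(=O)C3(C(C#N)=C(N)Oc4c(N)cc5nc6ccccc6nc5c43)c3ccccc32)c1`, is compared with compound 2 through a single change (3-methylphenyl in place of 2-methylphenyl on an aromatic nitrogen). The two share every other atom and bond.

Given that compound 2 sits at the limit (the limit of > 50000 nM in this assay, at which 2 of the 2 values shown sit), the step from compound 2 to compound 3 is expected to be none beyond the scatter, a step that the limit leaves unreadable from compound 2 to compound 3. Compound 3 is accordingly estimated at 60000 nM in this assay, with a range from 25000 nM to 150000 nM, and most likely another limit rather than a number.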

Compound 3, half-maximal inhibitory concentration: > 50000 nM
Compound 3 gave a limit, no number (the forecaster's own chance of this, stated with the estimate: 80%); the middle value lies beyond the limit too.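

Compound 3 also stops at a limit, so no step can be read between compound 2 and compound 3 in this assay: the limit of > 50000 nM in this assay, at which 3 of the 3 values shown sit.

The compounds shown leave open whether 3-methylphenyl and 2-methylphenyl on the triazole differ at all, and which change would give a number rather than a limit.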